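Adding bromo to compound 2

A few compounds are considered here, and "the series" means these few. Any claim that something is new, unique, unknown or untested is made for them only; others in the source may bear on it.

In a functional assay on HeLa cells (Homo sapiens) for antiproliferative activity, read by MTT assay, with a stated time of 48 h (a higher number here means a weaker inhibitor, a lower number a stronger inhibitor), compound 1 `c1ccc(-c2nn(-c3ccccc3)cc2-c2nc3ccccc3[nH]2)cc1` gives 1550 nM and compound 2 `Clc1ccc(-c2nn(-c3ccccc3)cc2-c2nc3ccccc3[nH]2)cc1` gives 1650 nM. Among the measured compounds shown here, compound 2 thus stands level with compound 1, its only measured neighbour, within the scatter. For the measured compounds named here, the one measured step, a 1.1-fold higher number from compound 1 to compound 2 (0.03 log units; within the scatter), is chloro in place of hydrogen on an aromatic carbon, and it lies within the scatter.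

Compound 3 `Clc1ccc(-c2nn(-c3ccccc3)cc2-c2nc3cc(Br)ccc3[nH]2)cc1` follows from compound 2 by one change: bromo in place of hydrogen on an aromatic carbon. This is bromo in place of hydrogen on an aromatic carbon, on a six-membered aromatic ring of carbon only, part of a fused or bridged system of two rings. Going by the values given here, no step on that ring has been measured, so the range stays wide. The chloro step, a 1.1-fold higher number from compound 1 to compound 2 (0.03 log units; within the scatter), gives no reason to expect a shift beyond the scatter. The expected step, a 1.3-fold lower number from compound 2 to compound 3 (0.10 log units; within the scatter), is therefore estimated to stay within it. For compound 3 the estimate is 1300 nM, with an expected range from 500 nM to 3000 nM.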

Compound 3, half-maximal inhibitory concentration: 2160 nM
Estimate against measurement, compound 3: 1.7-fold (0.22 log units) below, within the range that was stated.
By their numbers in this assay, from the lowest: compounds 1, 2 and 3 (each within the scatter of the next).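

In this assay, among the compounds shown here, bromo in place of hydrogen on an aromatic carbon of the six-membered aromatic ring of carbon only, part of a fused or bridged system of two rings, gives a 1.3-fold higher number from compound 2 to compound 3 (0.12 log units; within the scatter), the only measured step on that ring. This position therefore accepts one added heavy atom, a bromine, without a shift beyond the scatter, and compound 3 stays level with compound 2. No available evidence bears on the reason for this result.

Still open, from the compounds shown here alone, is whether an amine, a carboxylic acid or a methoxy group on this carbon would move the number beyond the scatter. Also open, going by these compounds, is whether bromo would read the same on the other aromatic carbons of this ring.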